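A Methyl Branch on the Ester Chain: Expected Cytotoxicity

The source may report more compounds than this note shows. Statements on the series, on what has been measured and on what is new or still open speak of the compounds shown alone.

Compound 1, `CCCCCCCCC(=O)NCC(C)(C)CC1=C(O)C(=O)c2ccccc2C1=O`, gives 16700 nM in an ADME assay on Vero cells (Chlorocebus sabaeus) for cytotoxicity, read by reporter gene assay, with a stated time of 4 days; a higher number here means a weaker inhibitor, a lower number a stronger inhibitor. Compound 2, `CCCCCCCCCC(=O)NCC(C)(C)CC1=C(O)C(=O)c2ccccc2C1=O`, gives 15000 nM. Compound 3, `CCCCCCCC(=O)OCC(C)(C)CC1=C(O)C(=O)c2ccccc2C1=O`, reaches only a limit of the assay, > 258000 nM.

The change from compound 1 to compound 2 is methyl in place of hydrogen on a saturated chain carbon, eight bonds along the chain from a carbonyl carbon. Its step, a 1.1-fold lower number from compound 1 to compound 2 (0.05 log units; within the scatter), is small. Compound 4, `CCCCCCC(C)C(=O)OCC(C)(C)CC1=C(O)C(=O)c2ccccc2C1=O`, has not yet been measured; it differs from compound 3 by methyl in place of hydrogen on a saturated chain carbon bound to a carbonyl carbon and a saturated chain carbon. This is the same kind of change, but not the same one: in the first pair the new methyl sits on a saturated chain carbon eight bonds along the chain from a carbonyl carbon, whereas in the second pair it sits on a saturated chain carbon bound to a carbonyl carbon and a saturated chain carbon. How the core of compound 3 differs from that of compound 1 is not broken down here.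

Compound 3 sits at the limit of > 258000 nM in this assay, at which 1 of the 3 values shown sits, so only a limit is known for it. Beside the small measured step, the step from compound 3 to compound 4 is expected to be small as well, a step that the limit leaves unreadable from compound 3 to compound 4. Compound 4 is therefore estimated at 300000 nM, between 100000 nM and 1000000 nM, most likely again reported only as a limit.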

Compound 4, half-maximal inhibitory concentration: 450 nM
Estimate against measurement, compound 4: 670-fold (2.82 log units) above, outside the stated range (below it).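

Compound 3 is known only through a limit of the assay, > 258000 nM. Measured against that limit in this assay, methyl in place of hydrogen on a saturated chain carbon bound to a carbonyl carbon and a saturated chain carbon gives an at least 570-fold lower number from compound 3 to compound 4 (2.75 log units; beyond the scatter), so this kind of change did not bring a step of the same size on the two cores: the same change on two cores in this assay, a 1.1-fold lower number (0.05 log units; within the scatter) from compound 1 to compound 2 and an at least 570-fold lower number (2.75 log units; beyond the scatter) from compound 3 to compound 4, at least 510-fold (2.71 log units) apart, beyond the scatter of two such steps

This does not show why the steps differ: the new methyl sits at a different place on the chain in each pair and the cores differ too, and these two pairs cannot separate those differences.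

Still open, as far as these compounds go, is whether a methyl on the chain carbon bound to the carbonyl carbon would give a similar step on the core of compound 1, and whether a methyl eight bonds along the chain from a carbonyl carbon would leave the core of compound 3 little changed. Also open, from the compounds shown here alone, is how an ethyl group or a fluorine atom at the place of the new methyl in compound 4 would read.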